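The compounds below may be only part of what the source reports. "The series", "measured", "known", "first", "only" and "open" are said of these compounds alone.

Compound 1 `CC(C)(C)OC(=O)N1CCC[C@H]1C(=O)NCC1CCc2nc(N)sc2C1`: in an assay with sodium channel protein type 4 subunit alpha (Homo sapiens) as the target, read by patch clamp (a higher number here means a weaker inhibitor, a lower number a stronger inhibitor), compound 1 gives > 30000 nM, which is a limit of the assay and not a number. Compound 2 `Nc1nc2c(s1)C[C@@H](NC(=O)c1ccc[nH]1)CC2`: in this assay compound 2 gives > 30000 nM, also a limit. Compound 3 `Nc1nc2c(s1)C[C@@H](NC(=O)c1cc(Br)c[nH]1)CC2`: in this assay compound 3 gives > 30000 nM, again a limit.

Compound 3 therefore sits at the limit of > 30000 nM in this assay, at which 3 of the 3 values shown sit, with no number of its own. The only step among these compounds, a step that the two limits leave unreadable from compound 2 to compound 3, runs between two limits and so gives no readable size. Compound 4 `Nc1nc2c(s1)C[C@@H](NC(=O)c1cc(Br)c(Br)[nH]1)CC2` differs from compound 3 by bromo in place of hydrogen on an aromatic carbon. Among the measured compounds shown here, no measured step bears readably on this change, and nothing among the values hints at a move away from the limit. The expected step is a number no higher from compound 3 to compound 4 (the limit leaves the size open), that is, none beyond the scatter. For compound 4 in this assay the estimate is 30000 nM, between 10000 nM and 100000 nM, most likely reported once more only as a limit.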

Compound 4, half-maximal inhibitory concentration: 15000 nM
Beside the measured number, compound 4's estimate is 2.0-fold (0.30 log units) above it; the measured number falls inside the stated range.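

In this assay, putting bromo on the aromatic carbon next to the ring nitrogen, next to the ring atom that already bears a bromo group, gives an at least 2.0-fold lower number from compound 3 to compound 4 (0.30 log units; that floor lies within the scatter). Among the compounds shown here, compound 4 is thus the only compound here with a number of its own, so this position offers a first readable reference point: the limit of > 30000 nM in this assay, at which 3 of the 4 values shown sit.

As far as these compounds go, whether bromo at this carbon gives a number without the neighbouring bromo stays open. So does the effect of a chloro, a methyl or an amine at this carbon.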